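The compounds below may be only part of what the source reports. "The series", "measured", "known", "first", "only" and "open" are said of these compounds alone.

Measured in a functional assay on U-87MG ATCC cells for antiproliferative activity against U-87 MG (Homo sapiens), read by MTT assay, with a stated time of 48 h, tested at 100 uM; on this read-out lower numbers stand for a stronger effect and higher numbers for a weaker effect at the one concentration tested:
compound 1 `COc1ccc(-c2nc(C)c(C(=O)CSc3nc(N)c(C#N)c(-c4ccc(Cl)cc4)n3)s2)cc1` gives 3.9%
compound 2 `COc1ccc(-c2nc(C)c(C(=O)CSc3nc(N)c(C#N)c(-c4ccccc4)n3)s2)cc1` gives 5.25%
compound 3 `Cc1nc(-c2ccc(Cl)cc2)sc1C(=O)CSc1nc(N)c(C#N)c(-c2ccc(Cl)cc2)n1` gives 1.65%

Compound 3 holds the smallest of the three numbers, but nothing separates it from the others: a number 2.3 percentage points lower from compound 1 to compound 3 (within the scatter) lies within the scatter, and the gap between compound 3 and compound 2 is likewise within the scatter, so the three compounds cannot be ranked in this assay on these numbers. All three sit at the low end of the read-out at the single concentration tested.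

Compound 4 `Cc1nc(-c2ccc(Cl)cc2)sc1C(=O)CSc1nc(N)c(C#N)c(-c2ccccc2)n1` is the next member to be run. Against compound 3 the change is hydrogen in place of chloro on an aromatic carbon.

Among the compounds with values here, one measured step bears directly on this exchange. Within the pair compound 1 and compound 2, the same replacement, hydrogen in place of chloro on an aromatic carbon, gave a number 1.4 percentage points higher from compound 1 to compound 2 (within the scatter), a move too small to stand out from repeat measurements. Within the data shown here, with only that one precedent, and no other pair showing a larger effect of this exchange, no step beyond the scatter is expected here; the estimate for compound 4 therefore means a number 1.4 percentage points higher from compound 3 to compound 4 (within the scatter). Compound 4 is expected to give 3% in this assay, with the estimate ranging from -2% to 10%.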

Compound 4, a percentage reported as activity, at one concentration (the size of the read-out at that concentration, not a potency): 4.59%
Estimate against measurement, compound 4: 1.6 percentage points below; measured number inside the range.
By their numbers in this assay, from the lowest: compounds 3, 1, 4 and 2 (each within the scatter of the next).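

The change of 4-chlorophenyl to phenyl now has a second reading in this assay, with a number 2.9 percentage points higher from compound 3 to compound 4 (within the scatter), and it agrees with the first: the same change on two cores in this assay, a number 1.4 percentage points higher (within the scatter) from compound 1 to compound 2 and a number 2.9 percentage points higher (within the scatter) from compound 3 to compound 4, 1.6 percentage points apart, within the scatter of two such steps

The exchange of chloro in place of methoxy also gains a second pair, with a number 0.7 percentage points lower from compound 2 to compound 4 (within the scatter), and its two readings agree as well: the same change on two cores in this assay, a number 2.3 percentage points lower (within the scatter) from compound 1 to compound 3 and a number 0.7 percentage points lower (within the scatter) from compound 2 to compound 4, 1.6 percentage points apart, within the scatter of two such steps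

Taken together, the four compounds form a closed set of two single changes, and neither change, on either core, moves the number beyond the scatter at the one concentration tested.

All four numbers sit at the low end of the read-out at that single concentration, so the compounds shown leave open whether these changes would give a stronger or weaker effect at lower concentrations. Also open, going by these compounds, is the effect of a group of a different kind on the same aromatic carbon, such as an amine or a carboxylic acid in place of the chloro.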